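A few compounds are considered here, and "the series" means these few. Any claim that something is new, unique, unknown or untested is made for them only; others in the source may bear on it.

Within the data shown here, compound 1, `Fc1ccc(-c2cc(-c3ccc4[nH]ccc4c3)on2)cc1`, is the only compound here with a measured number in a functional assay on COLO 320 cells (Homo sapiens) for cytotoxicity, read by WST assay, with a stated time of 72 h; on this read-out lower numbers stand for stronger inhibition and higher numbers for weaker inhibition; in that test compound 1 gives 13900 nM. Compound 2, `COc1ccc(-c2cc(-c3cc4ccccc4n3C)on2)cc1`, yields no number: compound 2 gives > 100000 nM, a limit of the assay rather than a measured value, and it sits at the limit of > 100000 nM in this assay, at which 1 of the 2 values shown sits. Among the measured compounds shown here, because no two measured compounds differ in a single place, no step size can be read from these two compounds. Compound 3, `COC(=O)c1ccc(-c2cc(-c3ccc4[nH]ccc4c3)on2)cc1`, is the compound not yet tested. It differs from compound 1 by methoxycarbonyl in place of fluoro on an aromatic carbon. For the measured compounds named here, with no measured step to lean on, the expected change in this assay is none beyond the usual scatter, in either direction. The step that this expectation means is estimated as a 1.1-fold higher number from compound 1 to compound 3 (0.03 log units; within the scatter). Compound 3 is therefore expected to give about 15000 nM in this assay, in an estimated range from 4000 nM to 60000 nM.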

Compound 3, half-maximal inhibitory concentration: > 100000 nM
Compound 3: only a limit was reported; the forecaster's own chance of this, stated with the estimate: 15%; at least 6.6-fold (0.82 log units) between middle value and limit.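

In this assay, compound 3 gives > 100000 nM, which is a limit of the assay and not a measured number. Placing methoxycarbonyl instead of fluoro on this aromatic carbon, para to a large group, gives an at least 7.1-fold higher number from compound 1 to compound 3 (0.85 log units; beyond the scatter), so this place on the ring does not accept every group alike, and this single change is enough to lose the modest activity of compound 1. Only the lower bound of the step can be read, since compound 3 sits at the end of the assay's range: the limit of > 100000 nM in this assay, at which 2 of the 3 values shown sit.

The compounds shown leave open whether the whole methoxycarbonyl group matters or only part of it, which a carboxylic acid or a primary amide at the same place could help to separate. They also leave open whether a small atom such as chlorine would behave like fluoro here.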